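The compounds below may be only part of what the source reports. "The series", "measured", "known", "first", "only" and "open" are said of these compounds alone.

Series notes, two compounds measured, one to come.

Compound 1 `C=C1C(=O)O[C@@H](C2CCCCC2)[C@H]1c1ccccc1` is tested in a functional assay on BXPC-3 cells (Homo sapiens) for cytotoxicity, read by MTT assay, with a stated time of 72 h, tested at 10 uM (on this read-out higher numbers stand for a weaker effect at the one concentration tested and lower numbers for a stronger effect), and gives 95%. Compound 2 `C=C1C(=O)O[C@@H](c2c(F)c(F)c(F)c(F)c2F)[C@H]1C` gives in this assay a value of 89%. Compound 1 stands at the higher of the two numbers, but the gap to compound 2 lies within the usual scatter, so the two values show no real difference on this read-out; both stand for a weak effect at the single concentration.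

Compound 3 `C=C1C(=O)O[C@@H](c2ccccc2)[C@H]1c1ccccc1` is not yet measured. It differs from compound 1 in one place: phenyl in place of cyclohexyl on a saturated ring carbon. For the measured compounds named here, no step between measured compounds bears on this change, so there is nothing in the measured pair that would point to a shift in either direction.

The expectation for compound 3 is therefore a step from compound 1 of about a number 5 percentage points lower from compound 1 to compound 3 (within the scatter), that is, none beyond the scatter. Compound 3 is estimated at 90%, with a range from 70% to 105%.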

Compound 3, a percentage reported as activity, at one concentration (the size of the read-out at that concentration, not a potency): 8%
Beside the measured number, compound 3's estimate is 82 percentage points above it; measured number outside the range, below it.
By their numbers in this assay, from the lowest: compound 3; then compounds 2 and 1 (each within the scatter of the next).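

In this assay, phenyl in place of cyclohexyl on the saturated ring carbon next to the ring oxygen gives a large step, a number 87 percentage points lower from compound 1 to compound 3 (beyond the scatter). This position is therefore not indifferent to the group it carries: two groups with the same count of 6 heavy atoms, each a six-membered ring of carbon only, separate a weak effect from a strong one at the single concentration tested, and the aromatic ring goes with the strong effect. No measurement at hand gives a reason for the step.

This single pair does not show whether the strong effect depends on the aromatic ring itself or would extend to other groups at this position. It also leaves open how an amine or a carboxylic acid on that phenyl, or a longer chain in its place, would read out.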